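Benzyl swap on the shared core: compound 1 to compound 3

A few compounds are considered here, and "the series" means these few. Any claim that something is new, unique, unknown or untested is made for them only; others in the source may bear on it.

Measured so far:
compound 1 `CCCSc1nc(N/N=C(\C)c2ccccc2O)c2nnn(Cc3ccco3)c2n1` — 4760 nM
compound 2 `C#CCSc1nc(N/N=C(\C)c2ccccc2O)c2nnn(Cc3ccccc3)c2n1` — 3820 nM

Both compounds were tested in a functional assay on MGC-803 cells (Homo sapiens) for antiproliferative activity, read by MTT assay, with a stated time of 72 h; a lower number here means a stronger inhibitor, a higher number a weaker inhibitor. Compound 1 gives 4760 nM and compound 2 gives 3820 nM; these two numbers lie within the usual scatter of each other, so no order between them can be read. Compound 1 carries the higher of the two numbers, but only by a margin that repeated measurement would blur. Compound 2 differs from compound 1 in more than one place, so its number says nothing on its own about the group on the saturated chain carbon bound to an aromatic nitrogen.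

Among the measured compounds shown here, the next compound, compound 3 `CCCSc1nc(N/N=C(\C)c2ccccc2O)c2nnn(Cc3ccc(Cl)cc3)c2n1`, keeps the propyl thioether and the hydrazone side of compound 1 and changes only one group: 4-chlorophenyl in place of furan-2-yl on a saturated chain carbon bound to an aromatic nitrogen. For the measured compounds named here, no measured pair isolates this change. Going by the values given here, the two numbers so far suggest that the shared core tolerates an aryl in this position with little effect, so the step from compound 1 to compound 3 is expected to be small, if anything toward a lower number, and likely within the scatter: a 1.4-fold lower number from compound 1 to compound 3 (0.13 log units; within the scatter). Compound 3 is therefore estimated at 3500 nM, with a range from 1500 nM to 8000 nM.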

Compound 3, half-maximal inhibitory concentration: 7100 nM
Beside the measured number, compound 3's estimate is 2.0-fold (0.31 log units) below it; the measured number falls inside the stated range.
By their numbers in this assay, from the lowest: compounds 2, 1 and 3 (each within the scatter of the next).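

In this assay, among the compounds shown here, the exchange of (furan-2-yl)methyl for 4-chlorobenzyl on the shared core gives the only single-place comparison so far at this position: a 1.5-fold higher number from compound 1 to compound 3 (0.17 log units; within the scatter). For the compounds shown here, with the propyl thioether and the hydrazone side held constant, this result shows that replacing a five-membered aromatic ring carrying one hetero atom with a larger six-membered aromatic ring of carbon only, bearing chlorine, gives no step that can be read beyond the scatter, so the position accepts both rings in this assay without a separable difference. No measurement is available that would explain this result or link it to any property of either group.

The compounds shown leave open whether any group on the saturated chain carbon bound to an aromatic nitrogen can move the number beyond the scatter, for example a benzyl ring bearing an amine or a carboxylic acid, or a longer chain ending in the same ring. They also leave open how the chlorine contributes, which would need an unsubstituted benzyl group paired with the propyl thioether for a single-place comparison with compound 3.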